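The compounds below may be only part of what the source reports. "The series", "measured", "known", "first", "only" and "open" are said of these compounds alone.

Among the compounds with values here, compound 1 `Cc1ccc(C(=O)Nc2ncc(-c3ccccc3)o2)cc1` is the only member of this small set with a number rather than a limit: in a toxicity assay on THP-1 cells (Homo sapiens) for inhibition (on this read-out lower numbers stand for higher toxicity in this test and higher numbers for lower toxicity in this test), compound 1 gives 26000 nM. Compound 2 `COc1ccc(-c2cnc(NC(=O)c3ccccc3C)n2C)cc1` reaches only a limit of this assay, at > 100000 nM. Compound 3 `COc1ccc(-c2cnc(NC(=O)c3ccccc3F)n2C)cc1` likewise reaches only a limit of this assay, at > 100000 nM. The difference between the core of compound 1 and the core of compound 2 is not broken down here.

From compound 2 to compound 3 the change is fluoro in place of methyl on an aromatic carbon. Its effect is a step that the two limits leave unreadable from compound 2 to compound 3; that it cannot be read rests on (the limit of > 100000 nM in this assay, at which 2 of the 3 values shown sit).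

Compound 4 `O=C(Nc1ncc(-c2ccccc2)o1)c1ccc(F)cc1` differs from compound 1 by the same kind of change, (fluoro in place of methyl on an aromatic carbon). It is not the same change: in compound 2 to compound 3 the place is ortho to a large group, whereas in compound 1 to compound 4 it is para to a large group. Within the data shown here, the measured pair therefore gives no readable size to lean on, and the expectation for compound 4 rests on compound 1 alone, whose value of 26000 nM is the only number available. A small step is expected, a 1.2-fold higher number from compound 1 to compound 4 (0.06 log units; within the scatter), within the usual scatter. Compound 4 is thus expected to give about 30000 nM in this assay, with a range from 12000 nM to 90000 nM.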

Compound 4, half-maximal cytotoxic concentration: 17000 nM
The estimate for compound 4 lay 1.8-fold (0.25 log units) above the measured number; measured number inside the range.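

In this assay the exchange of 4-methylphenyl for 4-fluorophenyl on the core of compound 1 gives (a 1.5-fold lower number from compound 1 to compound 4 (0.18 log units; within the scatter)), so on this core the replacement of methyl by fluoro stays within the usual scatter of repeated measurements and gives no readable effect in either direction. Within the data shown here, the only other pair with this kind of change, compound 2 and compound 3, sits on a different core, and its step cannot be read because both of its values are limits of the assay rather than numbers: (the limit of > 100000 nM in this assay, at which 2 of the 4 values shown sit). The series therefore shows one small step on one core, which does not establish that the change carries over from one core to the other, nor that it would fail to do so.

The compounds shown leave open how an amine, a carboxylic acid or a longer chain in place of the methyl on the core of compound 1 would read in this assay, and whether any of these would produce a step beyond the scatter. They also leave open how the replacement of methyl by fluoro would read on the core of compound 2 if both partners gave numbers rather than limits.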